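Acetyl for methyl on the shared core

This account rests on a few compounds, and the source may have more. Where it says the series, first, only, none or still open, it means among the compounds named here.

Among the measured compounds shown here, in a functional assay on the whole organism with Mus musculus as the target, in the maximal electroshock model, with a stated time of 4 h (on this read-out higher numbers stand for an effect only at larger amounts of compound and lower numbers for an effect already at smaller amounts), compound 1 `O=C(CCC(=O)c1ccccc1)Nc1nc2ccc(Br)cc2s1` gives 300 mg/kg, while compound 2 `Cc1ccc2nc(NC(=O)CCC(=O)c3ccccc3)sc2c1` gives 100 mg/kg, the lowest of the two numbers so far; the only measured step, a 3.0-fold lower number from compound 1 to compound 2 (0.48 log units; beyond the scatter), is modest. Compound 3 `CC(=O)c1ccc2nc(NC(=O)CCC(=O)c3ccccc3)sc2c1` carries acetyl in place of methyl on an aromatic carbon. For the measured compounds named here, no measured step exchanges methyl for acetyl at this position, so the one known step gives only a sense of scale, not a direction. For compound 3 a step of about no change at the digits printed from compound 2 to compound 3 (within the scatter) is therefore expected, within the scatter. Compound 3 is estimated at 100 mg/kg, with a range from 30 mg/kg to 300 mg/kg.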

Compound 3, minimum effective dose: 100 mg/kg
For compound 3 middle estimate and measured number coincide at the digits printed; low and high end bracket the measured number.
By their numbers in this assay, from the lowest: compounds 2 and 3 (each within the scatter of the next); then compound 1.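

In this assay the exchange of methyl for acetyl on the aromatic carbon gives no change at the digits printed from compound 2 to compound 3 (within the scatter) even though the entering group brings one hydrogen-bond acceptor and a double bond outside aromatic rings. Acetyl in place of bromo gives a 3.0-fold lower number from compound 1 to compound 3 (0.48 log units; beyond the scatter) so bromo is the group of the three that stands apart, with both other groups on the lower side. No measurement on hand accounts for these steps.

Open, on these data alone, is whether an amine, a carboxylic acid or a longer chain at this position would keep the number of compound 3. Also open, as far as these compounds go, is whether a hydrogen in place of these groups would do the same.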